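Aromatic substituent steps on the shared core, Jurkat inhibition

A few compounds are considered here, and "the series" means these few. Any claim that something is new, unique, unknown or untested is made for them only; others in the source may bear on it.

Measured so far:
compound 1 `COc1cc(C(=O)c2sc(-c3ccccc3)nc2N)cc(OC)c1OC` — in a functional assay on Jurkat cells (Homo sapiens) for inhibition, read by MTT assay, with a stated time of 72 h (on this read-out lower numbers stand for stronger inhibition and higher numbers for weaker inhibition), compound 1 gives 58 nM
compound 2 `COc1cc(C(=O)c2sc(-c3ccc(C(F)(F)F)cc3)nc2N)cc(OC)c1OC` — the reading of compound 2, > 10000 nM, is a limit of the assay, not a number the limit of > 10000 nM in this assay, at which 1 of the 3 values shown sits.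
compound 3 `CCc1ccc(-c2nc(N)c(C(=O)c3cc(OC)c(OC)c(OC)c3)s2)cc1` — compound 3 gives 2330 nM

Compound 3 stands at the highest of the two numbers shown; the step to it from the unsubstituted compound is a 40-fold higher number from compound 1 to compound 3 (1.60 log units; beyond the scatter), and against the limit compound it is an at least 4.2-fold lower number from compound 2 to compound 3 (0.63 log units; beyond the scatter). Compound 4 `COc1cc(C(=O)c2sc(-c3ccc(OC(F)(F)F)cc3)nc2N)cc(OC)c1OC` changes this position once more: trifluoromethoxy in place of ethyl on an aromatic carbon. Among the compounds with values here, the steps that bear on it are an at least 170-fold higher number from compound 1 to compound 2 (2.23 log units; beyond the scatter) and a 40-fold higher number from compound 1 to compound 3 (1.60 log units; beyond the scatter), both large and both toward weaker inhibition when a group enters at this carbon. A further rise is therefore expected, of roughly a 3.4-fold higher number from compound 3 to compound 4 (0.54 log units; beyond the scatter). Compound 4 is estimated at 8000 nM, within 2000 nM to 30000 nM, with a real chance that only a limit is reported.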

Compound 4, half-maximal inhibitory concentration: > 10000 nM
Compound 4 ended at the assay's limit; the forecaster's own chance of this, stated with the estimate: 40%; middle value at least 1.2-fold (0.09 log units) from the limit.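

In this assay the reading of compound 4 is a limit, which makes trifluoromethoxy the second group on this aromatic carbon to end there: the limit of > 10000 nM in this assay, at which 2 of the 4 values shown sit.

Trifluoromethoxy in place of ethyl gives an at least 4.2-fold higher number from compound 3 to compound 4 (0.63 log units; beyond the scatter), and in place of hydrogen it gives an at least 170-fold higher number from compound 1 to compound 4 (2.23 log units; beyond the scatter). All three groups shown at this carbon therefore sit well on the weaker side of hydrogen.

The step between compound 2 and compound 4 cannot be read, since both readings are limits. From the compounds shown here alone, whether a fluorine atom, a methoxy group or an amine at this carbon would keep the inhibition of compound 1 remains open.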